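Restoring a benzylamine on a stalled diaryl ether scaffold

The source may report more compounds than this note shows. Statements on the series, on what has been measured and on what is new or still open speak of the compounds shown alone.

Compound 2 `CCN1CCN(Cc2c(OC)cc(Oc3cccc(Nc4ccccc4)c3)cc2OC)CC1` stands at the weak end of the measured pair. In a functional assay on HCT-116 cells (Homo sapiens) for inhibition, read by MTT assay, with a stated time of 72 h (a lower number here means a stronger inhibitor, a higher number a weaker inhibitor), compound 2 gives > 20000 nM, which is a limit of the assay and not a number. Compound 1 `COc1cc(Oc2cccc(Nc3ccccc3)c2)cc(OC)c1CNCc1ccc(Cl)cc1` differs from it only at the saturated chain carbon bound to an aromatic carbon, and in this assay compound 1 gives 3310 nM. Among the compounds with values here, the step of an at least 6.0-fold higher number from compound 1 to compound 2 (0.78 log units; beyond the scatter) is the one measured change that bears on compound 3, and its far end sits at the limit of > 20000 nM in this assay, at which 1 of the 2 values shown sits. Compound 3 `COc1cc(Oc2cccc(Nc3ccccc3)c2)cc(OC)c1CNCc1ccc(Br)cc1` carries (4-bromobenzyl)amino in place of 4-ethylpiperazin-1-yl on a saturated chain carbon bound to an aromatic carbon. This change largely reverses the measured step, with bromine standing where compound 1 carries chlorine. Compound 3 is expected to recover most of that loss, with an estimated at least 6.6-fold lower number from compound 2 to compound 3 (0.82 log units; beyond the scatter), because the opposite move gave an at least 6.0-fold higher number from compound 1 to compound 2 (0.78 log units; beyond the scatter). The estimate for compound 3 is 3000 nM, within a range from 1000 nM to 9000 nM.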

Compound 3, half-maximal inhibitory concentration: 6230 nM
For compound 3 the middle estimate is 2.1-fold (0.32 log units) below the measured one, within the range that was stated.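

In this assay, (4-bromobenzyl)amino on a saturated chain carbon bound to an aromatic carbon brings the read-out back to a measurable level, with an at least 3.2-fold lower number from compound 2 to compound 3 (0.50 log units; beyond the scatter), so the loss seen with 4-ethylpiperazin-1-yl is reversed by a second halogenated benzylamine and not by the chlorinated one alone. Compound 2 stands at a limit of the assay and not at a number, so the full size of that step stays unknown: the limit of > 20000 nM in this assay, at which 1 of the 3 values shown sits.

Bromo in place of chloro on an aromatic carbon gives a 1.9-fold higher number from compound 1 to compound 3 (0.27 log units; within the scatter), so these two halogens are not told apart here.

The compounds shown leave open whether any halogen is needed, which a plain benzylamino or a 4-methoxybenzylamino group would test. They also leave open whether the recovery depends on the amine hydrogen, which a piperazine carrying a 4-chlorobenzyl group would help to settle.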